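Hydroxyalkyl triazole variants of a furazan amidoxime series

A few compounds are considered here, and "the series" means these few. Any claim that something is new, unique, unknown or untested is made for them only; others in the source may bear on it.

Measured compounds:
compound 1, `CCCCc1cn(CCNc2nonc2/C(=N/O)Nc2ccc(F)c(Br)c2)nn1`, 830 nM
compound 2, `OCCc1cn(CCNc2nonc2/C(=N/O)Nc2ccc(F)c(Br)c2)nn1`, 1170 nM
compound 3, `OCCCCc1cn(CCNc2nonc2/C(=N/O)Nc2ccc(F)c(Br)c2)nn1`, 1080 nM

In an assay on isolated protein for inhibition of Indoleamine 2,3-dioxygenase 2 (Homo sapiens) (a higher number here means a weaker inhibitor, a lower number a stronger inhibitor), compound 3 gives 1080 nM, which stands second highest of the three numbers; its nearest neighbour is compound 2 at 1170 nM, and the furthest is compound 1 at 830 nM, both within the scatter of it. The steps among the measured compounds are all small: a 1.4-fold higher number from compound 1 to compound 2 (0.15 log units; within the scatter), a 1.3-fold higher number from compound 1 to compound 3 (0.11 log units; within the scatter) and a 1.1-fold lower number from compound 2 to compound 3 (0.03 log units; within the scatter). None of them lies beyond the scatter, so neither the presence of a hydroxy group nor the length of the chain on the triazole has so far moved this assay in a way that can be trusted.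

Compound 4, `CCC(O)c1cn(CCNc2nonc2/C(=N/O)Nc2ccc(F)c(Br)c2)nn1`, is not yet measured. It differs from compound 3 in one place: 1-hydroxypropyl in place of 4-hydroxybutyl on an aromatic carbon. The earlier steps shown here bear on it in that each also exchanged one hydroxyalkyl or alkyl chain for another at the same aromatic carbon, and each stayed within the scatter. The step from compound 3 to compound 4 is therefore expected to be a 1.1-fold lower number from compound 3 to compound 4 (0.03 log units; within the scatter), with no direction beyond the scatter. Compound 4 is estimated at 1000 nM, expected between 500 nM and 2100 nM.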

Compound 4, half-maximal inhibitory concentration: 947 nM
Estimate against measurement, compound 4: 1.1-fold (0.02 log units) above, within the range that was stated.
By their numbers in this assay, from the lowest: compounds 1, 4, 3 and 2 (each within the scatter of the next).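

Placing the hydroxy group on the chain carbon named by 1-hydroxypropyl, rather than further out as in 2-hydroxyethyl and 4-hydroxybutyl, is new at this aromatic carbon, and in this assay it leaves the number within the scatter of each earlier compound: against 4-hydroxybutyl (a 1.1-fold lower number from compound 3 to compound 4 (0.06 log units; within the scatter)), against 2-hydroxyethyl (a 1.2-fold lower number from compound 2 to compound 4 (0.09 log units; within the scatter)) and against butyl (a 1.1-fold higher number from compound 1 to compound 4 (0.06 log units; within the scatter)). Among these four compounds, then, neither the location of the hydroxy group along the chain nor the exchange of butyl for 1-hydroxypropyl gives a step that can be trusted, and the position has so far accepted each of these chains without a readable change. No measurement is available that would explain this flat result.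

From the compounds shown here alone, whether an amine or a carboxylic acid in place of the hydroxy group, or a chain longer than 4-hydroxybutyl, would move the number beyond the scatter remains open. Going by these compounds, it also remains open whether these chains would behave alike if the bromine or the fluorine on the shared core were exchanged for another group.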